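This account rests on a few compounds, and the source may have more. Where it says the series, first, only, none or still open, it means among the compounds named here.

Compound 1 `C=C1C(=O)[C@]23C[C@@]1(O)CC[C@H]2c1ccc(O)c(C)c1[C@@H]3Cn1cc(-c2ccc(F)cc2)nn1` gives 660 nM in a functional assay on HL-60 cells (Homo sapiens) for cytotoxicity, read by MTT assay, with a stated time of 4 days (on this read-out lower numbers stand for stronger inhibition and higher numbers for weaker inhibition), the lower of the two numbers shown, with the other number lying within the scatter of it. Compound 3 `C=C1C(=O)[C@]23C[C@@]1(O)CC[C@H]2c1ccc(OS(=O)(=O)c2ccc(C)cc2)c(C)c1[C@@H]3Cn1cc(-c2ccc(F)cc2)nn1` gives 1290 nM in this assay, and a 2.0-fold higher number from compound 1 to compound 3 (0.29 log units; within the scatter). Compound 2 `C=C1C[C@]23C[C@@]1(O)CC[C@H]2c1ccc(O)c(C)c1[C@@H]3Cn1cc(-c2ccccc2)nn1` returns only a limit, > 20000 nM, which is the limit of > 20000 nM in this assay, at which 1 of the 3 values shown sits. Compound 4 `C=C1C(=O)[C@]23C[C@@]1(O)CC[C@H]2c1ccc(O)c(C)c1[C@@H]3Cn1cc(-c2ccc(OC)cc2)nn1` differs from compound 1 by methoxy in place of fluoro on an aromatic carbon. Going by the values given here, no measured step touches this position: the step from compound 1 to compound 3 changes the oxygen on the aromatic ring and stays within the scatter, while compound 2 differs from compound 1 in two places, so its limit cannot be set against compound 1 alone. For compound 4 no step beyond the scatter is therefore expected, a 1.2-fold higher number from compound 1 to compound 4 (0.08 log units; within the scatter). Compound 4 is estimated at 800 nM, between 300 nM and 2500 nM.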

Compound 4, half-maximal inhibitory concentration: 1150 nM
Beside the measured number, compound 4's estimate is 1.4-fold (0.16 log units) below it, within the range that was stated.
By their numbers in this assay, from the lowest: compounds 1, 4 and 3 (each within the scatter of the next). At a limit, above all of these: compound 2.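

First measured change at the 4-fluorophenyl group: in this assay, going to 4-methoxyphenyl gives a 1.7-fold higher number from compound 1 to compound 4 (0.24 log units; within the scatter), so at this place, para to a large group, methoxy in place of fluoro produces no step beyond the scatter. Nothing measured here gives a cause for this step.

Open, from the compounds shown here alone, is whether an amine or a carboxylic acid at this place would also stay within the scatter. Also open is which of the two differences between compound 1 and compound 2 accounts for the limit of compound 2.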